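Removing One Chloro from Compound 3

The compounds below may be only part of what the source reports. "The series", "measured", "known", "first", "only" and "open" are said of these compounds alone.

Measured in a functional assay on HeLa cells (Homo sapiens) for antiproliferative activity, read by resazurin assay; on this read-out higher numbers stand for weaker inhibition and lower numbers for stronger inhibition:
- compound 1 `CCSC(=S)SCC(=O)c1ccc(OC)cc1` gives 2510 nM
- compound 2 `CCSC(=S)SCC(=O)c1ccc(OC(F)F)cc1` gives 3980 nM
- compound 3 `CCSC(=S)SCC(=O)c1ccc(Cl)c(Cl)c1` gives 7940 nM

Compound 3 lies within the scatter of compound 2 and beyond the scatter above compound 1. Compound 4 `CCSC(=S)SCC(=O)c1ccc(Cl)cc1` has hydrogen in place of chloro on an aromatic carbon and has not yet been measured. For the measured compounds named here, no measured step makes this change. Going by the values given here, the only single-place step, a 1.6-fold higher number from compound 1 to compound 2 (0.20 log units; within the scatter), concerns another group and stays small. A small move toward lower numbers, within the scatter, is therefore expected, and the estimated step is a 1.6-fold lower number from compound 3 to compound 4 (0.20 log units; within the scatter) here. Compound 4 is estimated at 5000 nM with 2500 nM to 10000 nM as its expected range.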

Compound 4, half-maximal inhibitory concentration: 5010 nM
Compound 4: the middle estimate sits 1.0-fold (0.00 log units) below what was measured; the range from low to high includes it.
By their numbers in this assay, from the lowest: compounds 1, 2, 4 and 3 (each within the scatter of the next, the first and the last beyond it).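

In this assay the step of a 1.6-fold lower number from compound 3 to compound 4 (0.20 log units; within the scatter) shows that this aromatic carbon tolerates either chloro or hydrogen without a change beyond the scatter. The remaining chloro also reads level with the oxygen-linked groups at its place, through a 1.3-fold higher number from compound 2 to compound 4 (0.10 log units; within the scatter) and through a 2.0-fold higher number from compound 1 to compound 4 (0.30 log units; within the scatter) in the same sentence of numbers, all within the scatter. No evidence on the cause is at hand. On these data alone, whether an amine or a carboxylic acid on this aromatic carbon would move the number beyond the scatter stays open.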